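This account rests on a few compounds, and the source may have more. Where it says the series, first, only, none or still open, it means among the compounds named here.

Measured compounds:
compound 1 `CCN(CC)C(=O)CN(c1cc(N(CC)CC)ccc1Cl)S(=O)(=O)c1ccc(OC)c(OC)c1`: 2410 nM
compound 2 `CCN(CC)C(=O)CN(c1cc(C(C)C)ccc1Cl)S(=O)(=O)c1ccc(OC)c(OC)c1`: 90 nM

Both compounds share one core and differ only in the group attached to one aromatic carbon. In a functional assay on CHO cells for inhibition of Orexin receptor type 2 (Homo sapiens), read by FLIPR and calcium flux (on this read-out lower numbers stand for stronger inhibition and higher numbers for weaker inhibition), compound 1 gives 2410 nM, while compound 2 gives 90 nM. For the measured compounds named here, that single exchange produced a 27-fold lower number from compound 1 to compound 2 (1.43 log units; beyond the scatter), so compound 2 stands as the lower of the two numbers measured so far, with compound 1 the only comparison.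

Compound 3 `CCN(CC)C(=O)CN(c1cc(N2CCCC2)ccc1Cl)S(=O)(=O)c1ccc(OC)c(OC)c1` has not yet been measured. It differs from compound 2 by pyrrolidin-1-yl in place of isopropyl on an aromatic carbon. The entering group, like the diethylamino group of compound 1, is an amino substituent carrying two carbon branches, here tied into a ring; the isopropyl group of compound 2 carries no nitrogen. Going by the values given here, the one measured step that bears on this change is the one from compound 1 to compound 2, which was large, and compound 3 moves back toward the kind of substituent found in compound 1. The expected step is therefore an 11-fold higher number from compound 2 to compound 3 (1.05 log units; beyond the scatter), a higher number in this assay. For compound 3 the estimate is 1000 nM, with a range from 300 nM to 4000 nM.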

Compound 3, half-maximal inhibitory concentration: 1610 nM
Estimate against measurement, compound 3: 1.6-fold (0.21 log units) below, and the stated range covers the measured number.
By their numbers in this assay, from the lowest: compound 2; then compounds 3 and 1 (each within the scatter of the next).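

In this assay, pyrrolidin-1-yl in place of isopropyl on this aromatic carbon gives an 18-fold higher number from compound 2 to compound 3 (1.25 log units; beyond the scatter), so a second amino substituent, this time with a ring, also falls far from compound 2. Tying the two carbon branches of diethylamino into a five-membered ring makes no readable difference, as the exchange gives a 1.5-fold lower number from compound 1 to compound 3 (0.18 log units; within the scatter), a step within the scatter. Across these three compounds, the two groups attached through nitrogen, in compound 1 and compound 3, both have much higher numbers than the group attached through carbon in compound 2, and none of the three goes against this pattern, although three compounds are a narrow basis for it.

Cyclopentyl, the all-carbon ring counterpart of pyrrolidin-1-yl, would help separate the effect of the attached nitrogen from that of the ring, while tert-butyl or a smaller dimethylamino group would test how far the pattern extends at this position. The data offer no independent measurement that could explain what lies behind these steps.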